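This account rests on a few compounds, and the source may have more. Where it says the series, first, only, none or still open, it means among the compounds named here.

Compound 1 `CC(C)c1ccc2c(CCCCNS(=O)(=O)c3ccccc3)cc(C(=O)O)c-2cc1` gives 70 nM
Compound 2 `CC(C)c1ccc2c(CCCCNS(=O)(=O)c3ccc(Cl)cc3)cc(C(=O)O)c-2cc1` gives 5.3 nM

In a functional assay (thoracic aorta) for inhibition, with Rattus norvegicus as the target (on this read-out higher numbers stand for weaker inhibition and lower numbers for stronger inhibition), compound 1 holds the higher of the two numbers, at 70 nM, so it is the weaker inhibitor of this pair. Compound 3 `CC(C)c1ccc2c(/C=C/C(=O)O)cc(CCCCNS(=O)(=O)c3ccccc3)c-2cc1` has not yet been measured. Its change from compound 1 is 2-carboxyethenyl in place of carboxy on an aromatic carbon. Within the data shown here, only one measured step exists, a 13-fold lower number from compound 1 to compound 2 (1.12 log units; beyond the scatter). That large step came from chloro in place of hydrogen on an aromatic carbon, so it says nothing direct about swapping the carboxy group. It does show that one small edit can move the number a long way in this series. No direction can be drawn from these data, so only a small shift is expected in this assay, with wide uncertainty. The expected step is a 1.3-fold higher number from compound 1 to compound 3 (0.11 log units; within the scatter). The estimate for compound 3 is 90 nM, with an expected range from 12 nM to 600 nM.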

Compound 3, half-maximal inhibitory concentration: 21000 nM
Estimate against measurement, compound 3: 230-fold (2.37 log units) below; the whole stated range lies below it.
By their numbers in this assay, from the lowest: compound 2; then compound 1; then compound 3.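

Replacing carboxy with 2-carboxyethenyl on this aromatic carbon of the five-membered ring gives a 300-fold higher number from compound 1 to compound 3 (2.48 log units; beyond the scatter) in this assay, which makes this position highly sensitive to the change. Inhibition is lost even though the counts of hydrogen-bond donors and acceptors stay the same and neither group carries a net charge, while the group grows from 3 heavy atoms to 5. No measurement shown explains why the number rises so steeply.

As far as these compounds go, it remains open whether the loss follows from the added length, the added double bond or both, and a 2-carboxyethyl or carboxymethyl group at this position would help separate those. From the compounds shown here alone, it is also open whether chloro on the benzene ring, which gave a 13-fold lower number from compound 1 to compound 2 (1.12 log units; beyond the scatter), would recover any inhibition in the 2-carboxyethenyl series.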